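Adding Isopentyloxy: The Step From Compound 2 to Compound 3

This account rests on a few compounds, and the source may have more. Where it says the series, first, only, none or still open, it means among the compounds named here.

Compound 1 `COc1cccc2c(=O)cc(/C=C/[S+](C)[O-])oc12`: 2200 nM
Compound 2 `C[S+]([O-])/C=C/c1cc(=O)c2ccccc2o1`: 1900 nM

Within the data shown here, in a functional assay on A549 cells (Homo sapiens) for cytotoxicity, with a stated time of 48 h (a higher number here means a weaker inhibitor, a lower number a stronger inhibitor), compound 2 stands lowest of the two numbers, and the single measured step, a 1.2-fold lower number from compound 1 to compound 2 (0.06 log units; within the scatter), lies within the scatter. Compound 3 `CC(C)CCOc1ccc2oc(/C=C/[S+](C)[O-])cc(=O)c2c1` differs from compound 2 by isopentyloxy in place of hydrogen on an aromatic carbon. Among the measured compounds shown here, only that one step bears on this change, and it concerned hydrogen in place of methoxy on an aromatic carbon, so nothing measured speaks to isopentyloxy itself. Compound 3 is therefore expected to give a 1.2-fold lower number from compound 2 to compound 3 (0.07 log units; within the scatter), no step beyond the scatter. The estimated value for compound 3 is 1600 nM, between 600 nM and 4500 nM.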

Compound 3, half-maximal inhibitory concentration: 1000 nM
Compound 3: the middle estimate sits 1.6-fold (0.20 log units) above what was measured; measured number inside the range.
By their numbers in this assay, from the lowest: compounds 3, 2 and 1 (each within the scatter of the next, the first and the last beyond it).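

In this assay, putting isopentyloxy on this aromatic carbon gives a 1.9-fold lower number from compound 2 to compound 3 (0.28 log units; within the scatter). The earlier compounds shown here showed only the exchange of methoxy and hydrogen, whereas this result shows that the much larger isopentyloxy can sit on this carbon of the shared core, meta to one fused ring and para to the other, with no step beyond the scatter. Nothing available explains this result.

Going by these compounds, whether methoxy or a longer chain on this same carbon would also stay within the scatter remains open. So does the effect of an amine or a carboxylic acid here.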